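Amine tail variation on a shared antiproliferative core

The compounds below may be only part of what the source reports. "The series", "measured", "known", "first", "only" and "open" are said of these compounds alone.

Compound 1 `CN(C)CCn1c(N)c(-c2nc3ccccc3n2C)c2nc(C#N)c(C#N)nc21` carries a dimethylamino tail. In a functional assay on HL-60 cells (Homo sapiens) for antiproliferative activity, read by MTT assay, with a stated time of 48 h (on this read-out lower numbers stand for stronger inhibition and higher numbers for weaker inhibition), compound 1 reaches only the assay limit > 50000 nM, as recorded in the limit of > 50000 nM in this assay, at which 1 of the 3 values shown sits. Compound 2 `CCN(CC)CCn1c(N)c(-c2nc3ccccc3n2C)c2nc(C#N)c(C#N)nc21` gives 8800 nM in this assay, and compound 3 `CN(C)CCCCn1c(N)c(-c2nc3ccccc3n2C)c2nc(C#N)c(C#N)nc21` gives 740 nM. The measured steps are an at least 5.6-fold lower number from compound 1 to compound 2 (0.75 log units; beyond the scatter), an at least 67-fold lower number from compound 1 to compound 3 (1.82 log units; beyond the scatter) and a 12-fold lower number from compound 2 to compound 3 (1.08 log units; beyond the scatter). Compound 4 `CCN(CC)CCCCn1c(N)c(-c2nc3ccccc3n2C)c2nc(C#N)c(C#N)nc21` is not yet measured; it differs from compound 3 by diethylamino in place of dimethylamino on a saturated chain carbon, four bonds along the chain from an aromatic nitrogen. The same kind of change links compound 1 to compound 2, (diethylamino in place of dimethylamino on a saturated chain carbon, two bonds along the chain from an aromatic nitrogen); the place differs, being two bonds along the chain from an aromatic nitrogen there and four bonds along the chain from an aromatic nitrogen here. The cores of compound 1 and compound 3 differ by 2-(dimethylamino)ethyl in place of dimethylamino on a saturated chain carbon, two bonds along the chain from an aromatic nitrogen. From the compounds shown here alone, for compound 4 a step of about a 1.9-fold lower number from compound 3 to compound 4 (0.27 log units; within the scatter) is expected, smaller than the earlier one, because an at least 5.6-fold lower number from compound 1 to compound 2 (0.75 log units; beyond the scatter) starts from a limit and its true size is unknown. Compound 4 is estimated at 400 nM, between 100 nM and 1500 nM.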

Compound 4, half-maximal inhibitory concentration: 700 nM
Compound 4: the middle estimate sits 1.8-fold (0.24 log units) below what was measured; the measured number falls inside the stated range.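

In this assay, the change from dimethylamino to diethylamino does not carry over at the same size from one core to the other: the same change on two cores in this assay, an at least 5.6-fold lower number (0.75 log units; beyond the scatter) from compound 1 to compound 2 and a 1.1-fold lower number (0.02 log units; within the scatter) from compound 3 to compound 4, at least 5.3-fold (0.73 log units) apart, beyond the scatter of two such steps With the change on the longer chain, the step reads a 1.1-fold lower number from compound 3 to compound 4 (0.02 log units; within the scatter), while 2-(diethylamino)ethyl in place of diethylamino gives a 13-fold lower number from compound 2 to compound 4 (1.10 log units; beyond the scatter). The step of an at least 71-fold lower number from compound 1 to compound 4 (1.85 log units; beyond the scatter) sets only a minimum, and the true size of the change on the shorter chain stays unknown, so no rule for other cores follows: the limit of > 50000 nM in this assay, at which 1 of the 4 values shown sits.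

The compounds shown leave open whether a longer chain would keep these values. They also leave open how a cyclic amine such as morpholine or piperidine would behave at the end of either chain.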